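Aryl ether to aryl thioether on the shared core

The compounds below may be only part of what the source reports. "The series", "measured", "known", "first", "only" and "open" are said of these compounds alone.

Measured so far:
compound 1 `Nc1cc(N)c2nc(-c3ccccc3)c(NCc3ccc(F)cc3)nc2c1` — in a functional assay on SK-MEL-2 cells (Homo sapiens) for inhibition, read by sulforhodamine B assay, with a stated time of 48 h (a lower number here means a stronger inhibitor of growth, a higher number a weaker inhibitor of growth), compound 1 gives < 100000 nM
compound 2 `COc1ccc(Sc2nc3cc(N)cc(N)c3nc2-c2ccccc2)cc1` — in this assay compound 2 gives < 100000 nM
compound 3 `Nc1cc(N)c2nc(-c3ccccc3)c(Oc3ccc(F)cc3)nc2c1` — in this assay compound 3 gives < 100000 nM

Each of these three numbers is a limit of the assay, not a measured number; this is the situation described by the limit of < 100000 nM in this assay, at which 3 of the 3 values shown sit. Compound 3 therefore stands at the same limit as the other two, and no ordering among compounds 1, 2 and 3 can be read from what is shown.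

Compound 4 `Nc1cc(N)c2nc(-c3ccccc3)c(Sc3ccc(F)cc3)nc2c1` differs from compound 3 in one place: (4-fluorophenyl)sulfanyl in place of 4-fluorophenoxy on an aromatic carbon.

The measured steps that touch this region are a step that the two limits leave unreadable from compound 1 to compound 3, a step that the two limits leave unreadable from compound 2 to compound 3 and a step that the two limits leave unreadable from compound 1 to compound 2. All three are unreadable in size. Nothing among them speaks for the change from aryl ether to aryl thioether moving the number beyond the scatter in either direction.

For compound 4 the expected value in this assay is 30000 nM, with a range from 5000 nM to 100000 nM. The step this estimate means, a step that the limit leaves unreadable from compound 3 to compound 4, is expected to be nil within the scatter, with a fair chance that the assay again reports only a limit.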

Compound 4, concentration for total growth inhibition: < 100000 nM
Compound 4: only a limit was reported; the forecaster's own chance of this, stated with the estimate: 65%; the middle value lies beyond the limit too.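

In this assay compound 4 gives < 100000 nM, a limit of the assay and not a number. The steps to compound 4 from compound 1, compound 2 and compound 3 cannot be read: the limit of < 100000 nM in this assay, at which 4 of the 4 values shown sit. On these data alone, whether (4-fluorophenyl)sulfanyl in place of 4-fluorophenoxy moves the number at all in this assay stays open.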